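The compounds below may be only part of what the source reports. "The series", "measured", "known", "first", "only" and "open" are said of these compounds alone.

Compound 1, `CCCCCOc1cccc2ccc(N)nc12`: 580 nM
Compound 2, `CC(CC(C)(C)C)Oc1cccc2ccc(N3CCCCC3)nc12`: > 2000 nM
Compound 3, `CCOCC(C)Oc1cccc2ccc(N)nc12`: not yet measured

Within the data shown here, in an assay on cells with melanin-concentrating hormone receptor 1 (Homo sapiens) as the target, read by radioligand binding (on this read-out higher numbers stand for weaker inhibition and lower numbers for stronger inhibition), compound 1 gives 580 nM, the only plain number among the two measured compounds. For compound 2 this assay reports only a limit, > 2000 nM, which is not a number but the edge of what the assay can read (the limit of > 2000 nM in this assay, at which 1 of the 2 values shown sits).

Compound 3 keeps the shared core of compound 1 and changes a single place: a group of 6 heavy atoms (5 carbon, 1 oxygen; no ring) in place of a group of 5 heavy atoms (5 carbon; no ring), on an oxygen on an aromatic ring. Among the measured compounds shown here, no pair of measured compounds differs in just one place, so there is no measured step to lean on for this change. The expectation for this assay is a small step from compound 1 to compound 3, at most modestly toward weaker inhibition, quite possibly within the usual scatter.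

On that basis compound 3 is estimated at 900 nM, with a range from 300 nM to 3000 nM, which means an expected step of a 1.6-fold higher number from compound 1 to compound 3 (0.19 log units; within the scatter).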

Compound 3, half-maximal inhibitory concentration: 1070 nM
Estimate against measurement, compound 3: 1.2-fold (0.08 log units) below, within the range that was stated.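

Among these compounds, this is the first measured step between two compounds that differ in just one place: in this assay, putting the group with 1 oxygen and 1 hydrogen-bond acceptor in place of pentyl, on an oxygen on an aromatic ring, gives a 1.8-fold higher number from compound 1 to compound 3 (0.27 log units; within the scatter). So this position accepts a chain carrying a hydrogen-bond acceptor without a change that can be told apart from the ordinary spread of repeated measurements. Nothing measured here explains why the swap leaves the reading within that spread.

A single step cannot show how much this position tolerates in general, so it supports no wider pattern. From the compounds shown here alone, whether a longer chain, a chain ending in an amine or a carboxylic acid, or a phenyl ring at this place would shift the number beyond the scatter remains open.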